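Benzyl in place of phenyl on the shared core

The source may hold more compounds than are shown below. What is called first, only, known or untested is meant among the compounds shown, and "the series" means these compounds.

Measured compounds:
compound 1 `Cc1ccc(-c2nnc(SCCOc3ccc(/C=C4\SC(=O)NC4=O)cc3)[nH]2)cc1`: 21.7%
compound 2 `O=C1NC(=O)/C(=C/c2ccc(OCCSc3nnc(-c4ccccc4)o3)cc2)S1`: 22.2%

In a functional assay on the whole organism (strain Wistar) with Rattus norvegicus as the target, with a stated time of 15 days, at a dose of 10 mg/kg by the oral route (a higher number here means a stronger effect of the compound at the dose given, a lower number a weaker effect), compound 1 gives 21.7%, and compound 2 gives 22.2%. Compound 2 stands beside compound 1 on these numbers: the two values lie within the usual scatter of each other, so neither can be placed above the other.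

Compound 3 `O=C1NC(=O)/C(=C/c2ccc(OCCSc3nnc(Cc4ccccc4)o3)cc2)S1` differs from compound 2 in one place, (benzyl in place of phenyl on an aromatic carbon). Among the compounds with values here, no pair of measured compounds carries this change, so the data give no step from which its effect could be sized. Both measured compounds sit close together, and the change adds only a single carbon to one aromatic ring of carbon only. The step from compound 2 to compound 3 is therefore expected to be small, a number 1.2 percentage points lower from compound 2 to compound 3 (within the scatter), in no direction beyond the scatter. Compound 3 is estimated at 21%, with a range from 10% to 34%.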

Compound 3, a percentage reported as activity, at one dose (the size of the read-out at that dose, not a potency): 20.5%
The estimate for compound 3 lay 0.5 percentage points above the measured number; the range from low to high includes it.
By their numbers in this assay, from the lowest: compounds 3, 1 and 2 (each within the scatter of the next).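

In this assay, benzyl in place of phenyl on an aromatic carbon of the five-membered aromatic ring with 2 nitrogen and 1 oxygen gives a number 1.7 percentage points lower from compound 2 to compound 3 (within the scatter), the only step at this position among the compounds shown. The exchange therefore leaves no effect that can be separated from the scatter at the single dose given, so compound 2 and compound 3 cannot be told apart on this read-out. No measurement shown here bears on why this is so.

The compounds shown leave open whether a longer chain such as phenethyl, or an amine on the same aromatic carbon, would give a step beyond the scatter. They also leave open whether a carboxylic acid on the benzyl ring of compound 3 would change the read-out at all.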